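Compound 2 and its benzyloxy relative, compound 4

This account rests on a few compounds, and the source may have more. Where it says the series, first, only, none or still open, it means among the compounds named here.

In an ADME assay on Vero cells (Chlorocebus sabaeus) for cytotoxicity, read by MTT assay, with a stated time of 72 h (on this read-out higher numbers stand for weaker inhibition and lower numbers for stronger inhibition), compound 1 (`CCOC(=O)c1c(C)[n+]([O-])c2cc(F)c(F)cc2[n+]1[O-]`) gives 30600 nM and compound 2 (`CCOC(=O)c1c(C)[n+]([O-])c2cc(-n3cncn3)c(F)cc2[n+]1[O-]`) gives 155000 nM while compound 3 (`CCOC(=O)c1c(C(F)(F)F)[n+]([O-])c2cc(-n3cncn3)c(F)cc2[n+]1[O-]`) gives 35400 nM on the same read-out. Compound 2 thus holds the highest number of the three.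

Compound 4 (`Cc1c(C(=O)OCc2ccccc2)[n+]([O-])c2cc(F)c(-n3cncn3)cc2[n+]1[O-]`) has not been measured yet. It differs from compound 2 in one place: phenyl in place of methyl on a saturated chain carbon bound to an oxygen next to a carbonyl group, which turns ethoxy into benzyloxy.

Two measured steps give a sense of scale. Putting 1H-1,2,4-triazol-1-yl in place of fluoro gave a 5.1-fold higher number from compound 1 to compound 2 (0.70 log units; beyond the scatter) and putting trifluoromethyl in place of methyl on an aromatic carbon gave a 4.4-fold lower number from compound 2 to compound 3 (0.64 log units; beyond the scatter) and both count as modest. Neither touches this chain, so they serve only as a guide to size. Going by the values given here, no measured pair varies the chain, which makes direction a weak call, but compound 2 already stands at the top of the set, and that leans towards a lower number.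

A modest move is expected in this assay and the estimated change is a 2.5-fold lower number from compound 2 to compound 4 (0.40 log units; beyond the scatter) on this reasoning. Compound 4 is estimated at 62000 nM with an expected range from 20000 nM to 170000 nM until it is measured.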

Compound 4, half-maximal inhibitory concentration: 123000 nM
Beside the measured number, compound 4's estimate is 2.0-fold (0.30 log units) below it; measured number inside the range.
By their numbers in this assay, from the lowest: compounds 1 and 3 (each within the scatter of the next); then compounds 4 and 2 (each within the scatter of the next).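

The ester chain is the place varied here, and in this assay the swap of ethoxy for benzyloxy gives a 1.3-fold lower number from compound 2 to compound 4 (0.10 log units; within the scatter). Going by these compounds alone, until now, the only steps available changed groups on aromatic carbons, and both lay beyond the scatter, so this pair adds the first sign that a site on the compound can take a much larger group, with a six-membered aromatic ring of carbon only in place of a methyl, without a readable shift on this read-out. No measurement at hand explains why the two compounds cannot be told apart here.

This is a single pair on a single core, so it leaves open whether benzyloxy would behave the same way alongside the trifluoromethyl of compound 3 or the two fluoro groups of compound 1. It also leaves open what a longer chain, such as butyl, a phenyl ring carrying a chloro group, or a carboxylic acid or an amide in place of the ester would do in this assay.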